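Swapping Furan for Thiophene in a Fused Core

The compounds below may be only part of what the source reports. "The series", "measured", "known", "first", "only" and "open" are said of these compounds alone.

Going by the values given here, compound 1, with the structure `COc1cc(C(=O)C2Sc3nnc(-c4cc(OC)c(OC)c(OC)c4)n3NC2c2ccco2)cc(OC)c1OC`, is the only compound with a numerical result in a functional assay on A549 cells (Homo sapiens) for cytotoxicity, read by MTT assay, with a stated time of 48 h; a higher number here means a weaker inhibitor, a lower number a stronger inhibitor: compound 1 gives 48300 nM. Compound 2, with the structure `COc1cc(-c2nnc3n2NC(c2ccco2)C(C(=O)C2CC2)S3)cc(OC)c1OC`, reaches only a limit of the assay in this assay, where compound 2 gives > 100000 nM; this is the limit of > 100000 nM in this assay, at which 1 of the 2 values shown sits. Among the compounds with values here, the one measured step, an at least 2.0-fold higher number from compound 1 to compound 2 (0.31 log units; beyond the scatter), concerns the group on the carbonyl carbon, not the saturated ring carbon changed here, so it does not bear directly on the step to compound 3.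

Compound 3, with the structure `COc1cc(C(=O)C2Sc3nnc(-c4cc(OC)c(OC)c(OC)c4)n3NC2c2cccs2)cc(OC)c1OC`, differs from compound 1 only in thiophen-2-yl in place of furan-2-yl on a saturated ring carbon. Within the data shown here, no measured pair shows what such a swap does in this assay. Since both rings are five-membered aromatic rings with one hetero atom, the step is expected to stay within the scatter. Compound 3 is therefore estimated to give 40000 nM, with a range from 15000 nM to 110000 nM. The expected step is a 1.2-fold lower number from compound 1 to compound 3 (0.08 log units; within the scatter), carrying real uncertainty given the limit seen for compound 2.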

Compound 3, half-maximal inhibitory concentration: > 100000 nM
Compound 3 ended at the assay's limit; the forecaster's own chance of this, stated with the estimate: 25%; at least 2.5-fold (0.39 log units) between middle value and limit.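

On the saturated ring carbon of the shared core, furan-2-yl and thiophen-2-yl do not behave alike, even though both are five-membered aromatic rings with one hetero atom and the same count of heavy atoms: in this assay, the swap gives an at least 2.0-fold higher number from compound 1 to compound 3 (0.31 log units; beyond the scatter). Compound 3 gives > 100000 nM, which is a limit of the assay and not a number, so this step shows only the smallest possible size of the change. This is the first result for this position, and it shows that a change away from compound 1 at this ring carbon, like the change on the carbonyl carbon in compound 2, can end at the limit, leaving compound 1 as the only compound here with a numerical result: the limit of > 100000 nM in this assay, at which 2 of the 3 values shown sit.

The compounds shown leave open whether another group on this ring carbon, such as a phenyl ring or a simple methyl group, would give a numerical result, and whether that number would be lower than that of compound 1. They also do not tell how far compound 3 truly lies from compound 1, or why the two differ.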